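The source may report more compounds than this note shows. Statements on the series, on what has been measured and on what is new or still open speak of the compounds shown alone.

The shared core is shown by compound 1, `CC(C)[C@H](NC(=O)COc1cccc2ccccc12)C(=O)N[C@@H](CC(=O)O)C(=O)COc1ccc(C(F)(F)F)cc1`, and the compounds are compared in a functional assay on Jurkat cells (Homo sapiens); on this read-out lower numbers stand for stronger inhibition and higher numbers for weaker inhibition. Compound 1 gives > 100000 nM, which is a limit rather than a measured number. Its one measured partner, compound 2, `CC(C)[C@H](NC(=O)COc1cccc2ccccc12)C(=O)N[C@@H](CC(=O)O)C(=O)COc1ccc(OC(F)(F)F)cc1`, gives 29100 nM in that assay. Among the measured compounds shown here, the single measured step, an at least 3.4-fold lower number from compound 1 to compound 2 (0.53 log units; beyond the scatter), concerns a different exchange at the same oxygen and so bears only loosely on the change in hand. Compound 3, `CC(C)[C@H](NC(=O)COc1cccc2ccccc12)C(=O)N[C@@H](CC(=O)O)C(=O)COc1ccc(F)c(F)c1F`, differs from compound 1 by 2,3,4-trifluorophenyl in place of 4-(trifluoromethyl)phenyl on an oxygen on a saturated carbon. For the measured compounds named here, no measured step covers this replacement; the only firm fact about the starting point is the limit of > 100000 nM in this assay, at which 1 of the 2 values shown sits, which places compound 1 at the edge of the measured range. Because compound 1 stands at the limit of > 100000 nM in this assay, at which 1 of the 2 values shown sits, the step to compound 3 is expected to be a modest lowering at best, with a sizeable chance that compound 3 again returns only a limit, as expressed by an at least 2.0-fold lower number from compound 1 to compound 3 (0.30 log units; that floor lies within the scatter). Compound 3 is therefore estimated at 50000 nM, with a range from 10000 nM to 200000 nM.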

Compound 3, half-maximal inhibitory concentration: 35800 nM
Compound 3: the middle estimate sits 1.4-fold (0.15 log units) above what was measured; low and high end bracket the measured number.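

In this assay, exchanging 4-(trifluoromethyl)phenyl for 2,3,4-trifluorophenyl on the oxygen gives an at least 2.7-fold lower number from compound 1 to compound 3 (0.44 log units; beyond the scatter), so a measurable value at this position does not depend on the trifluoromethoxy group of compound 2. Against that earlier partner, the new group gives a 1.2-fold higher number from compound 2 to compound 3 (0.09 log units; within the scatter), which means that two differently substituted phenyl groups on this oxygen cannot be told apart in this read-out. The step from the trifluoromethyl compound can be read only as a floor and not as a true size, because compound 1 stands at a limit: the limit of > 100000 nM in this assay, at which 1 of the 3 values shown sits.

The compounds shown leave open whether the fluorines matter at all, since neither an unsubstituted phenyl, a 4-fluorophenyl nor a 4-chlorophenyl appears among them to show how much of the value of compound 2 and compound 3 belongs to the substituents and how much to the ring itself. They also leave open whether a ring carrying an amine or a carboxylic acid, or a saturated ring such as cyclohexyl on the same oxygen, would move the number beyond the scatter around these two compounds.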